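The source may report more compounds than this note shows. Statements on the series, on what has been measured and on what is new or still open speak of the compounds shown alone.

Measured compounds:
- compound 1, `CC(C)=CCC/C(C)=C/CC/C(C)=C/CC[C@@H]1[C@@]2(C)CC/C(=N\OCc3cn(-c4ccc(Cl)cc4)nn3)C(C)(C)[C@@H]2CC[C@@]1(C)O`: 19900 nM
- compound 2, `CC(C)=CCC/C(C)=C/CC/C(C)=C/CC[C@@H]1[C@@]2(C)CC/C(=N\OCc3cn(-c4ccc(F)c(Cl)c4)nn3)C(C)(C)[C@@H]2CC[C@@]1(C)O`: 58900 nM

Going by the values given here, of the two compounds measured in a functional assay on HepG2 cells (Homo sapiens) for cytotoxicity, read by MTT assay, with a stated time of 48 h (on this read-out higher numbers stand for weaker inhibition and lower numbers for stronger inhibition), compound 1 gives the lowest number, with compound 2 as its only neighbour. Among the compounds with values here, the single measured step, a 3.0-fold higher number from compound 1 to compound 2 (0.47 log units; beyond the scatter), is modest but beyond the scatter. Compound 3, `CC(C)=CCC/C(C)=C/CC/C(C)=C/CC[C@@H]1[C@@]2(C)CC/C(=N\OCc3cn(-c4ccc(F)c(F)c4F)nn3)C(C)(C)[C@@H]2CC[C@@]1(C)O`, differs from compound 1 by 2,3,4-trifluorophenyl in place of 4-chlorophenyl on an aromatic nitrogen. Within the data shown here, only that one step bears on this change, as both replace the 4-chlorophenyl with another fluorine-bearing phenyl, so a modest rise in number is expected, a 1.8-fold higher number from compound 1 to compound 3 (0.25 log units; within the scatter). Compound 3 is therefore estimated at 35000 nM, with a range from 14000 nM to 90000 nM.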

Compound 3, half-maximal inhibitory concentration: 37700 nM
For compound 3 the middle estimate is 1.1-fold (0.03 log units) below the measured one; the measured number falls inside the stated range.
By their numbers in this assay, from the lowest: compounds 1, 3 and 2 (each within the scatter of the next, the first and the last beyond it).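

In this assay the 2,3,4-trifluorophenyl group on the aromatic nitrogen lies within the scatter of both other groups, as the step to it from the 4-chlorophenyl compound (a 1.9-fold higher number from compound 1 to compound 3 (0.28 log units; within the scatter)) and the step to it from the 3-chloro-4-fluorophenyl compound (a 1.6-fold lower number from compound 2 to compound 3 (0.19 log units; within the scatter)) show. At this position, 3 fluorine atoms in place of one chlorine therefore give no change that can be told from the scatter. Nothing available explains this result.

As far as these compounds go, whether an amine or a carboxylic acid on this phenyl would shift the number remains open, as does the effect of a longer chain in its place.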